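The source may hold more compounds than are shown below. What is called first, only, known or untested is meant among the compounds shown, and "the series" means these compounds.

The measured compounds:
compound 1 `COc1ccc(C2CC(c3ccc(OC)c(OC)c3)=NN2C(=O)CO[N+](=O)[O-])c(OC)c1`: in a functional assay on the whole organism (strain albino) for inhibition, with Rattus norvegicus as the target, read by paw edema, with stated times of 30 min and 3 h, at a dose of 100 mg/kg by the oral route (a higher number here means more inhibition at the dose given (going by the name of the read-out), a lower number less inhibition), compound 1 gives 58%.
compound 2 `COc1ccc(C2=NN(C(=O)CO[N+](=O)[O-])C(c3c(Cl)cccc3Cl)C2)cc1OC`: in this assay compound 2 gives 58%.
compound 3 `COc1ccc(C2CC(c3ccc(OC)c(OC)c3)=NN2C(=O)C(C)Br)c(OC)c1`: in this assay compound 3 gives 69%.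

Compound 4 `COc1ccc(C2=NN(C(=O)C(C)Br)C(c3c(Cl)cccc3Cl)C2)cc1OC` has not yet been tested in this assay. The exchange that leads to it has been made once already, from compound 1 to compound 2: 2,6-dichlorophenyl in place of 2,4-dimethoxyphenyl on a saturated ring carbon. That exchange gave no change at the digits printed from compound 1 to compound 2 (within the scatter). The two cores differ as follows: 1-bromoethyl in place of (nitrooxy)methyl on a carbonyl carbon, and that change gave a number 11 percentage points higher from compound 1 to compound 3 (beyond the scatter), leaving compound 3 highest of the three measured numbers. In compound 4 the same kind of change is made on the core of compound 3: 2,6-dichlorophenyl in place of 2,4-dimethoxyphenyl on a saturated ring carbon. The place differs only in that it is next to the ring atom that bears a (1-bromoethyl)carbonyl group rather than a ((nitrooxy)methyl)carbonyl group. Among the compounds with values here, because the first exchange gave no change at the digits printed from compound 1 to compound 2 (within the scatter), compound 4 is expected to show a number 2 percentage points lower from compound 3 to compound 4 (within the scatter). Compound 4 is thus estimated at 67%, likely between 55% and 78%.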

Compound 4, a percentage reported as inhibition, in the whole organism at one dose (the size of the read-out at that dose, not a potency): 60%
Compound 4: the middle estimate sits 7 percentage points above what was measured, and the stated range covers the measured number.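

In this assay, 2,6-dichlorophenyl in place of 2,4-dimethoxyphenyl gave a number 9 percentage points lower from compound 3 to compound 4 (within the scatter), and this exchange agrees across the two cores: the same change on two cores in this assay, no change at the digits printed (within the scatter) from compound 1 to compound 2 and a number 9 percentage points lower (within the scatter) from compound 3 to compound 4, 9 percentage points apart, within the scatter of two such steps. 1-Bromoethyl in place of (nitrooxy)methyl gave a number 2 percentage points higher from compound 2 to compound 4 (within the scatter), and this exchange also agrees across the two cores: the same change on two cores in this assay, a number 11 percentage points higher (beyond the scatter) from compound 1 to compound 3 and a number 2 percentage points higher (within the scatter) from compound 2 to compound 4, 9 percentage points apart, within the scatter of two such steps. Within the data shown here, both changes therefore carry over within the scatter, but this rests on only two cores, and it does not show that the step beyond the scatter seen on the core of compound 1 recurs on the core of compound 2, where the step stays within the scatter.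

The compounds shown leave open whether an amine or a longer chain in place of 1-bromoethyl would follow the same pattern. They also leave open how a carboxylic acid on the phenyl ring would behave.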